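A few compounds are considered here, and "the series" means these few. Any claim that something is new, unique, unknown or untested is made for them only; others in the source may bear on it.

Of the compounds shown here, three have been measured in a physicochemical assay for lipophilicity, measured as octanol-water partition; a lower number here means a more polar compound, a higher number a more lipophilic compound. Compound 1 `CCO/N=C/Nc1cc(Cl)c(OC(C)C)c(Cl)c1` gives 4.4 in this assay. Compound 2 `C=CCOc1c(Cl)cc(N/C=N/OCC)cc1Cl` gives 4.3 in this assay. Compound 3 `C#CCc1c(Cl)cc(N/C=N/OC(C)C)cc1Cl` gives 3.9 in this assay, the lowest of the three numbers; its gaps to compound 2 and compound 1 are both beyond the scatter.

Compound 1 and compound 2 differ in one place, (allyl in place of isopropyl on an oxygen on an aromatic ring). That change made a number 0.10 log units lower from compound 1 to compound 2 (within the scatter).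

Compound 4 `C#CCc1c(Cl)cc(N/C=N/OCC=C)cc1Cl` has not yet been measured in this assay. It differs from compound 3 by allyl in place of isopropyl on an oxygen. Among the measured compounds shown here, this is the same kind of change as the one from compound 1 to compound 2, though not the same: there the oxygen sat on an aromatic ring with an aromatic carbon as its other neighbour, here the oxygen's other neighbour is a double-bonded nitrogen. How the core of compound 3 differs from the core of compound 1 is not broken down here.

The step is expected to be a number 0.10 log units lower from compound 3 to compound 4 (within the scatter), resting on a number 0.10 log units lower from compound 1 to compound 2 (within the scatter). Compound 4 is therefore estimated at 3.8, between 3.4 and 4.2.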

Compound 4, partition coefficient: 3.7
Beside the measured number, compound 4's estimate is 0.10 log units above it, and the stated range covers the measured number.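

On two cores the swap of isopropyl for allyl was followed in this assay and gave a number 0.20 log units lower from compound 3 to compound 4 (within the scatter) and also a number 0.10 log units lower from compound 1 to compound 2 (within the scatter) so on both cores the step stays inside the usual variation between repeated measurements. Among the compounds shown here, this rests on only two pairs, and the oxygen has a different neighbour in each, an aromatic carbon in one and a double-bonded nitrogen in the other, so it shows that the step stayed small on these two cores, not that it will stay small on any other core. Nothing given here explains why the step is small on either core.

Still open, as far as these compounds go, is how the number would respond if a longer chain, such as hexyl, took the place of allyl on that oxygen. From the compounds shown here alone, an amine or a carboxylic acid at the end of such a chain is equally open, and the two pairs here offer no basis for predicting either case.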